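A few compounds are considered here, and "the series" means these few. Any claim that something is new, unique, unknown or untested is made for them only; others in the source may bear on it.

In an ADME assay on PANC-1 cells (Homo sapiens) for cytotoxicity, read by MTT assay (on this read-out lower numbers stand for higher toxicity in this test and higher numbers for lower toxicity in this test), compound 1 (`Cc1nc(-c2cccnc2)sc1-c1nnc(Cc2ccccc2)o1`) gives > 100 ug/mL as a limit of the assay and not as a number. Compound 2 (`Cc1nc(-c2cccnc2)sc1-c1nnc(-c2ccc(Br)cc2)o1`) gives > 100 ug/mL as a limit too, so no number fixes its standing in the series. Among the compounds with values here, the only measured step is a step that the two limits leave unreadable from compound 1 to compound 2 with 4-bromophenyl in place of benzyl on an aromatic carbon, and it offers no size to carry forward. The evidence so far comes down to the limit of > 100 ug/mL in this assay, at which 2 of the 2 values shown sit, for the series.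

The next change leads to compound 3 (`Cc1ccccc1-c1nnc(-c2sc(-c3cccnc3)nc2C)o1`) and is counted as 2-methylphenyl in place of 4-bromophenyl on an aromatic carbon with 2-methylphenyl in place of 4-bromophenyl on an aromatic carbon. With only the limit of compound 2 at > 100 ug/mL to start from, no step beyond the scatter is expected in this assay and no direction can be named. The estimated change is a step that the limit leaves unreadable from compound 2 to compound 3 as an expectation only. For compound 3 the estimated value is 110 ug/mL with an expected range from 50 ug/mL to 200 ug/mL and another report as a limit is the likelier outcome.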

Compound 3, half-maximal cytotoxic concentration: > 100 ug/mL
Compound 3: only a limit was reported; the forecaster's own chance of this, stated with the estimate: 80%; the middle value lies beyond the limit too.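

Compound 3 gives > 100 ug/mL in this assay, a limit of the assay and not a number, so its steps from compound 1 and compound 2 cannot be read. The compounds shown leave open whether any of these group changes moves this read-out at all, since the series rests on one shared result: the limit of > 100 ug/mL in this assay, at which 3 of the 3 values shown sit.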